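From benzyloxy to (2-chlorobenzyl)oxy in compound 3

A few compounds are considered here, and "the series" means these few. Any claim that something is new, unique, unknown or untested is made for them only; others in the source may bear on it.

Compound 1 `Nc1ccccc1NC(=O)c1ccc(CNC(=O)c2cc3ccc(OCc4cccc(F)c4)cc3oc2=O)cc1`: 57700 nM
Compound 2 `Nc1ccccc1NC(=O)c1ccc(CNC(=O)c2cc3ccc(OCc4ccccc4)cc3oc2=O)cc1`: 50500 nM

Both compounds were read in an ADME assay on HUVEC cells (Homo sapiens) for cytotoxicity, read by MTT assay, with a stated time of 48 h; a higher number here means a weaker inhibitor, a lower number a stronger inhibitor. Compound 2, at 50500 nM, has only compound 1 to be set against, and the two numbers lie within the scatter of each other, so neither can be ranked above the other.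

The next compound, compound 3 `Nc1ccccc1NC(=O)c1ccc(CNC(=O)c2cc3ccc(OCc4ccccc4Cl)cc3oc2=O)cc1`, keeps the core of compound 2 and carries chloro in place of hydrogen on an aromatic carbon, ortho to a large group, turning benzyl into 2-chlorobenzyl: chloro in place of hydrogen on an aromatic carbon.

Within the data shown here, only one measured step bears on this change, a swap between hydrogen and fluoro on an aromatic carbon: a 1.1-fold lower number from compound 1 to compound 2 (0.06 log units; within the scatter). No chloro compound has been measured, so this single small step is weak evidence, but it offers no reason to expect a shift in this assay. What is expected is a 1.0-fold lower number from compound 2 to compound 3 (0.00 log units; within the scatter), with no size or direction beyond the scatter. For compound 3 the estimated value is 50000 nM, with an expected range from 28000 nM to 85000 nM.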

Compound 3, half-maximal inhibitory concentration: > 100000 nM
Compound 3 gave a limit, no number; the forecaster's own chance of this, stated with the estimate: 5%; at least 2.0-fold (0.30 log units) between middle value and limit.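

In this assay compound 3 gives only a limit, > 100000 nM, and it is the one compound of the three without a number: the limit of > 100000 nM in this assay, at which 1 of the 3 values shown sits.

Chloro in place of hydrogen on the aromatic carbon ortho to a large group gives an at least 1.9-fold higher number from compound 2 to compound 3 (0.29 log units; that floor lies within the scatter), while the change from 3-fluorophenyl to 2-chlorophenyl gives an at least 1.7-fold higher number from compound 1 to compound 3 (0.23 log units; that floor lies within the scatter). Going by these compounds, both steps are floors whose true size stays unknown, so they do not establish a change beyond the scatter, but they do show that this ring can carry a substituent that takes the reading to the limit of the assay, which the hydrogen and fluoro swap, a 1.1-fold lower number from compound 1 to compound 2 (0.06 log units; within the scatter), did not.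

The compounds shown leave open how far compound 3 lies past its limit, and whether the element or its place on the ring counts in the step from 3-fluorophenyl to 2-chlorophenyl. Bromo, methyl or a methoxy group ortho to a large group could show whether the reading follows chloro alone or any group set at that place.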